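A few compounds are considered here, and "the series" means these few. Any claim that something is new, unique, unknown or untested is made for them only; others in the source may bear on it.

Measured so far in a functional assay on HeLa cells (Homo sapiens) for antiproliferative activity, read by MTT assay, with a stated time of 72 h; a lower number here means a stronger inhibitor, a higher number a weaker inhibitor:

Compound 1 `Cc1ccc2c(=O)c(CSC(=S)N3CCCCC3)coc2c1` gives > 25000 nM, a limit of the assay.
Compound 2 `O=c1c(CSC(=S)N2CCOCC2)coc2cc(Cl)ccc12` gives 2000 nM.
Compound 3 `Cc1ccc2c(=O)c(CSC(=S)N3CCCC3)coc2c1` gives 4400 nM.

Among the two numbers that are not limits, compound 3 has the higher one, and compound 2 sits at a lower number beyond the scatter. Within the data shown here, the one measured step that touches the group on the thiocarbonyl carbon is an at least 5.6-fold lower number from compound 1 to compound 3 (0.75 log units; beyond the scatter). That step starts from a limit. Its full size is not known.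

Compound 4 `Cc1ccc2c(=O)c(CSC(=S)N3CCOCC3)coc2c1` differs from compound 3 in one place: morpholin-4-yl in place of pyrrolidin-1-yl on a thiocarbonyl carbon. Among the measured compounds shown here, no measured pair shows this exact exchange on the same core. Compound 2 carries the morpholin-4-yl group on a differently substituted core and gives a number below that of compound 3, while compound 1 shows that a six-membered ring on this carbon can sit at the limit. These pull in opposite directions, so the expected step of a 1.1-fold higher number from compound 3 to compound 4 (0.06 log units; within the scatter) from compound 3 to compound 4 is estimated as small, with wide uncertainty. The estimate for compound 4 in this assay is therefore 5000 nM, within a range from 1500 nM to 25000 nM.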

Compound 4, half-maximal inhibitory concentration: 6100 nM
Compound 4: middle estimate off by 1.2-fold (0.09 log units), on the low side, and the stated range covers the measured number.
By their numbers in this assay, from the lowest: compound 2; then compounds 3 and 4 (each within the scatter of the next). At a limit, above all of these: compound 1.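

In this assay, there is a 1.4-fold higher number from compound 3 to compound 4 (0.14 log units; within the scatter) when morpholin-4-yl replaces pyrrolidin-1-yl on the thiocarbonyl carbon, so on the shared core this exchange, which adds a ring oxygen and a hydrogen-bond acceptor, separates the two compounds by no more than the scatter. With morpholin-4-yl held constant, the change on the core gives a 3.1-fold higher number from compound 2 to compound 4 (0.48 log units; beyond the scatter), as methyl replaces chloro on an aromatic carbon, which shows that this aromatic position also affects the read-out in this assay. The exchange of piperidin-1-yl for morpholin-4-yl gives an at least 4.0-fold lower number from compound 1 to compound 4 (0.61 log units; beyond the scatter), which shows that a six-membered ring on the thiocarbonyl carbon does not by itself bring a compound to the limit, but this step starts from a limit and so gives only a bound: the limit of > 25000 nM in this assay, at which 1 of the 4 values shown sits.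

The compounds shown leave open whether the difference between chloro and methyl carries over to cores bearing pyrrolidin-1-yl or piperidin-1-yl on the thiocarbonyl carbon. They also leave open how an open-chain diethylamino group or a piperazin-1-yl ring would behave on that carbon, and how fluoro or methoxy would behave on the aromatic carbon.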